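A few compounds are considered here, and "the series" means these few. Any claim that something is new, unique, unknown or untested is made for them only; others in the source may bear on it.

Of the compounds shown here, two from this series have been measured in a functional assay on MCF7 cells (Homo sapiens) for cytotoxicity, read by MTT assay, with a stated time of 72 h; on this read-out higher numbers stand for weaker inhibition and lower numbers for stronger inhibition. Compound 1, `Cc1cccc(CSc2cc(Cl)c(C)cc2S(=O)(=O)/N=C(\N)n2nccc2-c2ccccc2)c1`, gives 47000 nM in this assay. Compound 2, `Cc1cc(-c2ccccc2)n(/C(N)=N/S(=O)(=O)c2cc(C)c(Cl)cc2SCc2ccccc2C)n1`, carries the same kind of core with the groups arranged differently, and in this assay compound 2 gives 80000 nM. Of these two numbers, that of compound 1 sits at the bottom, but its gap to compound 2 lies within the usual scatter of repeated measurements, so the two readings cannot be told apart.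

Compound 3, `Cc1cc(S(=O)(=O)/N=C(\N)n2nccc2-c2ccccc2)c(SCc2cccc(C(F)(F)F)c2)cc1Cl`, has not yet been measured in this assay. It differs from compound 1 in one place: trifluoromethyl in place of methyl on an aromatic carbon, in words, trifluoromethyl in place of methyl on an aromatic carbon. Within the data shown here, no pair of measured compounds shows this change, so the data give no guide to its size. The expectation for the step from compound 1 to compound 3 is therefore a 1.2-fold lower number from compound 1 to compound 3 (0.07 log units; within the scatter), no larger than the scatter, in no settled direction. On that basis compound 3 is expected to give about 40000 nM in this assay, with a plausible range from 15000 nM to 110000 nM.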

Compound 3, half-maximal inhibitory concentration: 17000 nM
Estimate against measurement, compound 3: 2.4-fold (0.37 log units) above; measured number inside the range.
By their numbers in this assay, from the lowest: compound 3; then compounds 1 and 2 (each within the scatter of the next).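

In this assay, going from 3-methylbenzyl to 3-(trifluoromethyl)benzyl gives a 2.8-fold lower number from compound 1 to compound 3 (0.44 log units; beyond the scatter). Among these compounds, this is the first change that stands clear of the scatter: the readings of compound 1 and compound 2 could not be told apart, and no single-place step linked them, so the earlier numbers gave no sign that this assay would respond to any particular change. The new step shows that the group on this aromatic carbon, meta to a large group, can move the number, although it rests on a single pair of compounds and sets no general rule, and nothing available bears on the reason for the shift.

Going by these compounds, whether other groups at the same carbon, such as a chlorine atom, a nitrile, a methoxy group or a plain hydrogen, would take the number lower still or back up remains open. Also open, on these data alone, is whether trifluoromethyl would give a step of similar size at another carbon of the same ring, or when the rest of the molecule is changed.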